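A few compounds are considered here, and "the series" means these few. Any claim that something is new, unique, unknown or untested is made for them only; others in the source may bear on it.

Measured compounds:
Compound 1 `CCn1nccc1-c1ccccc1NCC1=NCCN1` in an in vitro functional assay on cells (Fibroblast) for agonist activity at Alpha-1D adrenergic receptor (Homo sapiens) (on this read-out lower numbers stand for an effect already at smaller amounts and higher numbers for an effect only at larger amounts of compound), gives < 100000 nM, which is a limit of the assay and not a number.
Compound 2 `CCCn1nccc1-c1ccccc1NCC1=NCCN1` gives < 100000 nM in this assay, again a limit of the assay rather than a number.
Compound 3 `Cn1cccc1-c1ccccc1NCC1=NCCN1` gives 251 nM in this assay.

Going by the values given here, compound 3 therefore supplies the only number among the three, the other two values sitting at the limit of < 100000 nM in this assay, at which 2 of the 3 values shown sit. The step from compound 1 to compound 2 is a step that the two limits leave unreadable from compound 1 to compound 2, the change being (methyl in place of hydrogen on a saturated chain carbon, two bonds along the chain from an aromatic nitrogen). The cores of compound 1 and compound 3 differ, but that difference is not broken down here.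

Compound 4 `CCn1cccc1-c1ccccc1NCC1=NCCN1` has not yet been measured. It differs from compound 3 by methyl in place of hydrogen on a saturated chain carbon bound to an aromatic nitrogen, the same kind of change as between compound 1 and compound 2, though here the carbon is bound to an aromatic nitrogen rather than two bonds along the chain from one. Since the measured step gives no readable size, the expectation for compound 4 rests on compound 3 and its 251 nM. With only a methyl added, compound 4 is expected to stay close, the estimated step being a 1.6-fold higher number from compound 3 to compound 4 (0.20 log units; within the scatter). Compound 4 is thus estimated at 400 nM, expected to fall between 100 nM and 2000 nM.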

Compound 4, half-maximal effective concentration: < 100000 nM
Compound 4: no number, only a limit; the forecaster's own chance of this, stated with the estimate: 5%; the middle value does not contradict the limit.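

Compound 4 gives < 100000 nM in this assay, which is a limit of the assay and not a number. No size can be read for the step from compound 3 to compound 4. What stays open is how compound 1, compound 2 and compound 4 compare with one another and with compound 3, the only compound with a number: the limit of < 100000 nM in this assay, at which 3 of the 4 values shown sit.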